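Methylsulfanyl in Place of Methoxy at a Carbonyl

A few compounds are considered here, and "the series" means these few. Any claim that something is new, unique, unknown or untested is made for them only; others in the source may bear on it.

Of the compounds shown here, two sharing a core have been tested in a functional assay on MDA-MB-231 cells (Homo sapiens) for cytotoxicity, read by sulforhodamine B assay, with a stated time of 72 h; a higher number here means a weaker inhibitor, a lower number a stronger inhibitor. Compound 1 `CCc1c(C)c(O)c(C)c(O)c1C(=O)SC` is one of them. In this assay compound 1 gives > 40000 nM, which is a limit of the assay rather than a number. Compound 2 `COC(=O)c1c(O)c(C)c(O)c(C)c1C(C)C` is the other. In this assay compound 2 gives > 40000 nM, again a limit rather than a measured number, so compound 2 stands among the compounds too weak to be resolved here. Compound 3 `CSC(=O)c1c(O)c(C)c(O)c(C)c1C(C)C` differs from compound 2 in one place: methylsulfanyl in place of methoxy on a carbonyl carbon. Within the data shown here, no measured pair shows this change on its own. In this assay the expected step is a step that the limit leaves unreadable from compound 2 to compound 3, nothing beyond the scatter, because compound 1 and compound 2 both sit at the limit of > 40000 nM in this assay, at which 2 of the 2 values shown sit. Compound 3 is therefore estimated at 50000 nM, within 15000 nM to 200000 nM, and most likely reported only as a limit again.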

Compound 3, half-maximal inhibitory concentration: > 40000 nM
Compound 3: only a limit was reported; the forecaster's own chance of this, stated with the estimate: 80%; the middle value lies beyond the limit too.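

Compound 3 adds no readable step to compound 1 or compound 2, because all three results are limits of the assay rather than numbers: the limit of > 40000 nM in this assay, at which 3 of the 3 values shown sit.

As far as these compounds go, whether methylsulfanyl in place of methoxy on a carbonyl carbon changes potency at all in this assay stays open.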